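The compounds below may be only part of what the source reports. "The series", "measured", "known", "first", "only" and "open" are said of these compounds alone.

Values in an ADME assay on Vero cells (Chlorocebus sabaeus) for cytotoxicity, read by MTT assay, with a stated time of 72 h; on this read-out higher numbers stand for lower toxicity in this test and lower numbers for higher toxicity in this test:

- compound 1 `CO/N=C1/C(=O)N(CCCn2cc(CN3CCC[C@@H]4CN(c5c(F)cc6c(=O)c(C(=O)O)cn(C7CC7)c6c5OC)C[C@@H]43)nn2)c2ccc(C)cc21`: 8 ug/mL
- compound 2 `COc1c(N2C[C@H]3CCCN(Cc4cn(CCCN5C(=O)/C(=N/O)c6cc(C)ccc65)nn4)[C@H]3C2)c(F)cc2c(=O)c(C(=O)O)cn(C3CC3)c12`: 8 ug/mL
- compound 3 `CCO/N=C1/C(=O)N(CCCn2cc(CN3CCC[C@@H]4CN(c5c(F)cc6c(=O)c(C(=O)O)cn(C7CC7)c6c5OC)C[C@@H]43)nn2)c2ccc(C)cc21`: 4 ug/mL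

Compound 3, at 4 ug/mL, stands within the usual scatter of both compound 1 and compound 2, so the three cannot be ranked in this assay. The next step leads to compound 4 `CCO/N=C1/C(=O)N(CCCn2cc(CN3CCC[C@@H]4CN(c5c(F)cc6c(=O)c(C(=O)O)cn(C7CC7)c6c5OC)C[C@@H]43)nn2)c2ccccc21` and is hydrogen in place of methyl on an aromatic carbon. Within the data shown here, no measured step touches that carbon. The three available steps all change the group on an oxygen: no change at the digits printed from compound 1 to compound 2 (within the scatter), a 2.0-fold lower number from compound 1 to compound 3 (0.30 log units; within the scatter) and a 2.0-fold lower number from compound 2 to compound 3 (0.30 log units; within the scatter). They therefore bear on the new change only indirectly, by showing that the series has so far stayed within the scatter. Among the measured compounds shown here, with no measured precedent for a direction, no shift beyond the scatter is expected in this assay. The expected outcome is a 1.3-fold higher number from compound 3 to compound 4 (0.10 log units; within the scatter), which would be no real change. For compound 4 the estimated value is 5 ug/mL, with an expected range from 2.5 ug/mL to 10 ug/mL.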

Compound 4, half-maximal cytotoxic concentration: 16 ug/mL
Compound 4: middle estimate off by 3.2-fold (0.51 log units), on the low side, and the stated range ends below it.
By their numbers in this assay, from the lowest: compounds 3, 1, 2 and 4 (each within the scatter of the next, the first and the last beyond it).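

In this assay, hydrogen in place of methyl on the aromatic carbon gives a 4.0-fold higher number from compound 3 to compound 4 (0.60 log units; beyond the scatter), the first step among these compounds to lie beyond the scatter, and its direction stands for lower toxicity in this test. The earlier steps all changed the group on an oxygen and stayed within the scatter, so this aromatic carbon, meta to a fused ring and para to a fused ring, is the first place shown where a single change moves the number. Nothing available explains the shift.

The compounds shown leave open whether the same change would give a similar step with methyl or hydrogen on the oxygen, as in compound 1 and compound 2. They also leave open how a chlorine, a methoxy or a trifluoromethyl group on that aromatic carbon would compare with methyl and hydrogen.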